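The source may hold more compounds than are shown below. What is called first, only, known or untested is meant among the compounds shown, and "the series" means these compounds.

Measured in a functional assay on CNE-2 cells (Homo sapiens) for cytotoxicity, read by sulforhodamine B assay, with a stated time of 48 h; a higher number here means a weaker inhibitor, a lower number a stronger inhibitor
Compound 1 `O=C(/C=C/c1ccc(Br)cc1)c1cccc(-c2cccc(F)c2)c1` gives 10500 nM
Compound 2 `O=C(/C=C/c1cccc(Br)c1)c1cccc(-c2cccc(F)c2)c1` gives 6550 nM

Among the compounds with values here, the one measured step is a 1.6-fold lower number from compound 1 to compound 2 (0.20 log units; within the scatter) and it leaves compound 2 level with compound 1, so neither stands out. Compound 3 `COc1ccccc1/C=C/C(=O)c1cccc(-c2cccc(F)c2)c1` has no number yet and differs from compound 2 as follows: 2-methoxyphenyl in place of 3-bromophenyl on a double-bonded chain carbon bound to a double-bonded chain carbon (2-methoxyphenyl in place of 3-bromophenyl, on a double-bonded chain carbon bound to a double-bonded chain carbon). The measured step only exchanged 4-bromophenyl for 3-bromophenyl at this same place. Within the data shown here, no measured compound carries 2-methoxyphenyl, so that step is a loose guide and gives no clear direction. In this assay the expected change is therefore none beyond the scatter, with a 1.1-fold lower number from compound 2 to compound 3 (0.04 log units; within the scatter) as the estimated step. For compound 3 the estimated value is 6000 nM (expected range 2000 nM to 18000 nM).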

Compound 3, half-maximal inhibitory concentration: 10400 nM
Beside the measured number, compound 3's estimate is 1.7-fold (0.24 log units) below it; the measured number falls inside the stated range.
By their numbers in this assay, from the lowest: compounds 2, 3 and 1 (each within the scatter of the next).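

In this assay, swapping bromine for a methoxy-bearing ring at this place on the chain leaves the number within the scatter of both bromine compounds (a 1.6-fold higher number from compound 2 to compound 3 (0.20 log units; within the scatter)) (a 1.0-fold lower number from compound 1 to compound 3 (0.00 log units; within the scatter)). So 2-methoxyphenyl, which brings an oxygen and a hydrogen-bond acceptor that 3-bromophenyl and 4-bromophenyl lack, cannot be told apart from either of them here, and all three compounds sit at one level. Nothing measured on these compounds accounts for this flat result.

Still open, from the compounds shown here alone, is whether any group at this place can move the number beyond the scatter, as all three compounds carry a substituted phenyl ring there. An amine or a carboxylic acid on that ring, or a longer chain in its place, would test this.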